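Returning to an Aromatic Ring: Expected Solubility of Compound 4

A few compounds are considered here, and "the series" means these few. Any claim that something is new, unique, unknown or untested is made for them only; others in the source may bear on it.

Measured so far:
Compound 1, `Cc1cc(NCc2ccccn2)n2ncc(-c3ccc(N(C)C)cc3)c2n1`: < 5000 nM
Compound 2, `Cc1cc(NCc2ccccn2)n2ncc(-c3ccsc3)c2n1`: 9000 nM
Compound 3, `Cc1cc(NCc2ccccn2)n2ncc(C3=CCOCC3)c2n1`: 171000 nM

Three compounds share one core and differ only in the group on the five-membered ring. In a physicochemical assay for solubility, read by HPLC, using the shake flask method, measured as kinetic solubility, with a stated time of 2 h, at pH 7.4 (on this read-out lower numbers stand for lower solubility and higher numbers for higher solubility), compound 3 gives 171000 nM, the highest of the two numbers shown. Compound 2 gives 9000 nM in this assay. For compound 1 the value < 5000 nM is a limit of the assay, not a number (the limit of < 5000 nM in this assay, at which 1 of the 3 values shown sits).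

Compound 4, `Cc1cc(NCc2ccccn2)n2ncc(-c3cccc(N)c3)c2n1`, carries a group of 7 heavy atoms (6 carbon, 1 nitrogen; one six-membered aromatic ring of carbon only) in place of a group of 6 heavy atoms (5 carbon, 1 oxygen; one six-membered non-aromatic ring with 1 hetero atom), on an aromatic carbon. Going by the values given here, two measured steps bear on this: an at least 34-fold higher number from compound 1 to compound 3 (1.53 log units; beyond the scatter) and a 19-fold higher number from compound 2 to compound 3 (1.28 log units; beyond the scatter). Both replaced an aromatic ring with the non-aromatic oxygen ring and both raised solubility well beyond the scatter. Compound 4 reverses that move, putting an aromatic six-membered ring back in, so a drop beyond the scatter is expected, moderated somewhat since the 3-aminophenyl brings a hydrogen-bond donor that the earlier aromatic groups lacked.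

Compound 4 is therefore expected to give 15000 nM, with a range from 4000 nM to 50000 nM. The step from compound 3 to compound 4 is estimated as an 11-fold lower number from compound 3 to compound 4 (1.06 log units; beyond the scatter).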

Compound 4, solubility: 160000 nM
Compound 4: the middle estimate sits 11-fold (1.03 log units) below what was measured; measured number outside the range, above it.
By their numbers in this assay, from the lowest: compound 2; then compounds 4 and 3 (each within the scatter of the next). At a limit, below all of these: compound 1.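

Exchanging the non-aromatic oxygen ring for 3-aminophenyl on this aromatic carbon gives a 1.1-fold lower number from compound 3 to compound 4 (0.03 log units; within the scatter) in this assay and so shows that an aromatic ring at this place need not go with a low number, which compound 1 and compound 2 had suggested. Among the aromatic groups themselves, 3-aminophenyl in place of thiophen-3-yl gives an 18-fold higher number from compound 2 to compound 4 (1.25 log units; beyond the scatter) on this read-out, and 3-aminophenyl in place of 4-(dimethylamino)phenyl gives an at least 32-fold higher number from compound 1 to compound 4 (1.50 log units; beyond the scatter) on the same read-out. The value of compound 1 is a limit of the assay and not a number, so that last step is only a floor: the limit of < 5000 nM in this assay, at which 1 of the 4 values shown sits.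

From the compounds shown here alone, what a plain phenyl ring or a 3-hydroxyphenyl group would give at this position remains open. So does whether the amine would give the same number at another place on the ring.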